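From 4-methylpyridin-2-yl to 2-chlorophenyl in compound 4

The source may report more compounds than this note shows. Statements on the series, on what has been measured and on what is new or still open speak of the compounds shown alone.

Measured compounds:
- compound 1 `Cc1ccnc(OC(c2ccc(C(F)(F)F)cc2)C2CCN(C(C)CCNC(=O)c3c(Cl)cncc3Cl)CC2)c1`: 33600 nM
- compound 2 `CCO/N=C(/c1ccc(Br)cc1)C1CCN(C(C)CCNC(=O)c2c(C)cc[n+]([O-])c2C)CC1`: > 177000 nM
- compound 3 `CCO/N=C(/c1ccc(Br)cc1)C1CCN(C(C)CCN(C)C(=O)c2c(C)cc[n+]([O-])c2C)CC1`: > 182000 nM

Among the measured compounds shown here, in an ADME assay on PBMC cells (Homo sapiens) for cytotoxicity (a lower number here means that less compound is tolerated, a higher number that more compound is tolerated), compound 1 gives 33600 nM, and this is the only plain number among the three results. Compound 2 reaches only an assay limit, > 177000 nM, in this assay. Compound 3 likewise reaches only an assay limit, > 182000 nM. For the measured compounds named here, the one measured step, a step that the two limits leave unreadable from compound 2 to compound 3, joins two limits and so its size cannot be read; it concerns methyl in place of hydrogen on an amide-type nitrogen, a change of a different kind from the one considered here.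

Compound 4 `CC(CCNC(=O)c1c(Cl)cncc1Cl)N1CCC(C(Oc2ccccc2Cl)c2ccc(C(F)(F)F)cc2)CC1` is compound 1 altered in one place: 2-chlorophenyl in place of 4-methylpyridin-2-yl on an oxygen on a saturated carbon. Going by the values given here, no measured step touches this part of the molecule, and compounds 2 and 3 share neither this oxygen-linked ring nor the dichloropyridine amide of compound 1. There is therefore no measured evidence pointing to a step in either direction in this assay, and the expectation is a change no larger than the usual scatter, with a wide band of uncertainty.

On that basis compound 4 is expected to give 33600 nM, within 11000 nM to 100000 nM, which corresponds to an estimated step of no change at the digits printed from compound 1 to compound 4 (within the scatter).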

Compound 4, half-maximal cytotoxic concentration: 4400 nM
Beside the measured number, compound 4's estimate is 7.6-fold (0.88 log units) above it; measured number outside the range, below it.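

In this assay, the ring on this oxygen proves able to move the result: 2-chlorophenyl in place of 4-methylpyridin-2-yl gives a 7.6-fold lower number from compound 1 to compound 4 (0.88 log units; beyond the scatter), so less of compound 4 is tolerated by the cells. This is the first step in the series shown whose size can be read, as the step between compound 2 and compound 3 joins two limits and cannot be read. Since the rest of the molecule stays the same, the difference traces to this one position, which makes the oxygen-linked ring a place that matters in this assay, and not a part that can be exchanged freely.

Nothing measured here explains why the number falls with this change. The swap also alters several things at once, removing the ring nitrogen and the methyl and bringing in a chlorine, and the compounds shown do not separate these parts; an unsubstituted phenyl ring or a pyridin-2-yl ring without the methyl on the same oxygen would be needed to tell which of them carries the step.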